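Inverting one ring stereocentre in the nitrophenyl lactone series

The source may hold more compounds than are shown below. What is called first, only, known or untested is meant among the compounds shown, and "the series" means these compounds.

For the measured compounds named here, in a functional assay on MCF7 cells (Homo sapiens) for antiproliferative activity, read by luminescence and CellTiter-Glo, with a stated time of 48 h (a higher number here means a weaker inhibitor, a lower number a stronger inhibitor), compound 1 `O=C1C=CC[C@H](/C=C/c2ccc([N+](=O)[O-])cc2)O1` gives 28800 nM, the only true number available so far in this small set. Compound 2 `C[C@@H](Cc1ccccc1)[C@H]1CCCC(=O)O1` reads > 100000 nM, which is a limit of the assay and not a number. No position in a ranking can be drawn from these two entries beyond what they show directly.

Compound 3 `O=C1C=CC[C@@H](/C=C/c2ccc([N+](=O)[O-])cc2)O1` is still to be measured. The change from compound 1 is the two compounds have the same atoms and bonds and differ only in configuration as drawn: 1 of 2 stereo elements differ; a stereocentre at a saturated ring carbon is drawn R in compound 1 and S in compound 3. Nothing leaves and nothing enters, so the comparison rests on configuration alone. Going by the values given here, no measured pair here tests a change of configuration, so the size and direction of this step cannot be read from the data. The working expectation in this assay is no step beyond the scatter, with a slight allowance towards a higher number, and a report of only a limit remains possible. The estimate starts from compound 1 at 28800 nM. The expected 1.2-fold higher number from compound 1 to compound 3 (0.08 log units; within the scatter) is small. Compound 3 is expected at 35000 nM, with an estimated range from 12000 nM to 100000 nM.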

Compound 3, half-maximal inhibitory concentration: > 100000 nM
Compound 3: no number, only a limit (the forecaster's own chance of this, stated with the estimate: 20%); middle value at least 2.8-fold (0.45 log units) away from the limit.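

Configuration at this ring position is not a silent feature of the series: in this assay, the record shows an at least 3.4-fold higher number from compound 1 to compound 3 (0.54 log units; beyond the scatter), and this step rests on a limit of the assay and not on a number. The earlier compounds shown here offered no pair that tested a change of configuration, and the step can be assigned to the saturated ring carbon drawn R in compound 1 and S in compound 3 because nothing else changes between them: the fact that compounds 1 and 3 differ only in the configuration as drawn. The result also shows how little room the read-out leaves at the weak end of the series, so the step has a lower bound but no measured size: the limit of > 100000 nM in this assay, at which 2 of the 3 values shown sit.

The compounds shown leave open how far compound 3 lies past the limit, and what happens when the second stereo element, which is the same in compounds 1 and 3, is changed. They also leave open whether the R configuration keeps its advantage in the series when the nitro group gives way to an amine or a carboxylic acid, or when a longer chain carries the phenyl ring.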